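From isopropyl to methyl on the carbonyl carbon

The source may hold more compounds than are shown below. What is called first, only, known or untested is meant among the compounds shown, and "the series" means these compounds.

compound 1 `COc1cc(C(=O)O)ccc1OCCCCOc1ccc(C(=O)C(C)C)c(O)c1C`: 73.1%
compound 2 `Cc1cc(C(=O)O)ccc1OCCCCOc1ccc(C(=O)C(C)C)c(O)c1C`: 76.9%
compound 3 `CC(=O)c1ccc(OCCCCOc2ccc(F)c(C(=O)O)c2)c(C)c1O`: 75.5%

In an assay on HEK293 cells for positive allosteric modulation of metabotropic glutamate receptor 2 (Rattus norvegicus), read by thallium flux, with a stated time of 2.5 min (a lower number here means a smaller maximal response, a higher number a larger maximal response), compound 1 has the lowest of the three numbers, yet both compound 3 and compound 2 lie within the scatter of it, so no order among the three can be claimed. Going by the values given here, the only measured step, a number 3.8 percentage points higher from compound 1 to compound 2 (within the scatter), stays within the scatter. Compound 4 `COc1cc(C(=O)O)ccc1OCCCCOc1ccc(C(C)=O)c(O)c1C` differs from compound 1 in one place: methyl in place of isopropyl on a carbonyl carbon. Among the compounds with values here, no measured step covers this change directly; compound 3 carries the acetyl group and its value is within the scatter of compound 1, which is the closest hint available. The step of a number 0.9 percentage points higher from compound 1 to compound 4 (within the scatter) is therefore expected to stay within the scatter. For compound 4 a value of 74% is estimated, with a range from 65% to 83%.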

Compound 4, largest response reached (reported as percent of maximum), in percent of the reference or control that the assay uses: 86.3%
Compound 4: the middle estimate sits 12.3 percentage points below what was measured; the whole stated range lies below it.
By their numbers in this assay, from the lowest: compounds 1, 3, 2 and 4 (each within the scatter of the next, the first and the last beyond it).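

In this assay, going by these compounds alone, exchanging isopropyl for methyl on the carbonyl carbon gives the first single-place step beyond the scatter: a number 13.2 percentage points higher from compound 1 to compound 4 (beyond the scatter). Within the data shown here, the maximal response at this position therefore depends on the group on the carbonyl carbon, a dependence that the earlier compounds could not show. Nothing available explains this step. The compounds shown leave open how an ethyl or cyclopropyl group on the same carbonyl carbon would read, and whether the acetyl step persists when methyl replaces methoxy on the aromatic carbon.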